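The source may report more compounds than this note shows. Statements on the series, on what has been measured and on what is new or still open speak of the compounds shown alone.

In a functional assay on Huh-7 cells (Homo sapiens) for antiproliferative activity, read by CCK-8 assay, with a stated time of 72 h (on this read-out lower numbers stand for stronger inhibition of growth and higher numbers for weaker inhibition of growth), compound 1 (`CCCNC(=O)c1ccc2c(ccn2-c2ncc3c(n2)N(c2ccn(C)n2)C(CC)C(=O)N3C)c1`) gives 7280 nM, compound 2 (`CCCCNC(=O)c1ccc2c(ccn2-c2ncc3c(n2)N(c2ccn(C)n2)C(CC)C(=O)N3C)c1`) gives 8670 nM and compound 3 (`CCNC(=O)c1ccc2c(ccn2-c2ncc3c(n2)N(C2CCCC2)[C@H](CC)C(=O)N3C)c1`) gives 596 nM. Compound 2 and compound 1 sit together, within the scatter, at the upper end of these numbers, while compound 3 has a clearly lower number than either.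

Compound 4 (`CCC1C(=O)N(C)c2cnc(-n3ccc4cc(C(=O)NC5CCCC5)ccc43)nc2N1c1ccn(C)n1`) follows from compound 2 by one change, cyclopentyl in place of butyl on an amide-type nitrogen. Going by the values given here, only one measured step bears on the group at this nitrogen, a 1.2-fold higher number from compound 1 to compound 2 (0.08 log units; within the scatter), and it is small. That step adds a methyl to a chain and does not test a ring, so it gives only weak guidance. No step beyond the scatter is therefore expected in this assay, though the uncertainty is wide. The expected change is a 1.3-fold lower number from compound 2 to compound 4 (0.13 log units; within the scatter), which would stay within the scatter. Compound 4 is estimated at 6500 nM, with an expected range from 3000 nM to 15000 nM.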

Compound 4, concentration for 50% growth inhibition: "not active" (no number reported)
For compound 4 the study gives words and no number; there is nothing to compare the estimate with.
By their numbers in this assay, from the lowest: compound 3; then compounds 1 and 2 (each within the scatter of the next).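

In this assay, going by these compounds alone, compound 4 is reported only as not active, without a number, and no step from compound 2 to compound 4 can be read. Nothing shown accounts for this result. The compounds shown leave open how far cyclopentyl in place of butyl shifts growth inhibition.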